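Sulfonamide anilides: ethyl to trifluoromethyl on the sulfonyl sulfur

The source may report more compounds than this note shows. Statements on the series, on what has been measured and on what is new or still open speak of the compounds shown alone.

Compound 1 `CCS(=O)(=O)Nc1ccc(NC(=O)c2ccc(Cl)cc2)cc1C` and compound 3 `Cc1cc(NC(=O)c2ccc(Cl)cc2)ccc1NS(=O)(=O)C(F)(F)F` share one core; compound 2 `CCS(=O)(=O)Nc1ccc(NC(=O)c2cccc(C(F)(F)F)c2)cc1C` and the unmeasured compound 4 `Cc1cc(NC(=O)c2cccc(C(F)(F)F)c2)ccc1NS(=O)(=O)C(F)(F)F` share another. The difference between the two cores is not broken down here. In an ADME assay on HEK293 cells (Homo sapiens) for cytotoxicity, read by MTT assay, with a stated time of 48 h (a lower number here means a stronger inhibitor, a higher number a weaker inhibitor), compound 1 gives 125000 nM, and compound 3 gives 201000 nM. The change between them is trifluoromethyl in place of ethyl on a sulfonyl sulfur, and it made a step of a 1.6-fold higher number from compound 1 to compound 3 (0.21 log units; within the scatter). In this assay compound 2 gives 210000 nM; this number lies within the scatter of both compound 1 and compound 3, so no order among the three is drawn. Compound 4 carries the same change on the core of compound 2: trifluoromethyl in place of ethyl on a sulfonyl sulfur. The place is identical in both pairs, a sulfonyl sulfur whose other neighbour is the sulfonamide nitrogen, so this is the same change. The earlier instance gave a 1.6-fold higher number from compound 1 to compound 3 (0.21 log units; within the scatter), a step within the scatter. On that basis a step of similar size is expected, a 1.4-fold higher number from compound 2 to compound 4 (0.15 log units; within the scatter). Compound 4 is estimated at 300000 nM in this assay, with an expected range from 150000 nM to 600000 nM.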

Compound 4, half-maximal inhibitory concentration: 131000 nM
For compound 4 the middle estimate is 2.3-fold (0.36 log units) above the measured one, outside the stated range (below it).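

In this assay, trifluoromethyl in place of ethyl on a sulfonyl sulfur gives a 1.6-fold lower number from compound 2 to compound 4 (0.20 log units; within the scatter), and the two instances of this change do not differ beyond the scatter: the same change on two cores in this assay, a 1.6-fold higher number (0.21 log units; within the scatter) from compound 1 to compound 3 and a 1.6-fold lower number (0.20 log units; within the scatter) from compound 2 to compound 4, 2.6-fold (0.41 log units) apart, within the scatter of two such steps

Both steps lie within the scatter, so on these two cores the change has no readable effect in this assay, and a step of that small size is what carries from one core to the other. The printed directions differ, but this is no reversal between the cores, no direction can be assigned to the change, and two pairs do not show that it would stay this small on other cores in the series.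

Open, going by these compounds, is whether a longer chain, such as propyl or butyl, on the sulfonyl sulfur would give a step beyond the scatter in this assay. Also open, on these data alone, is whether the change would behave the same on a core carrying an amine or a carboxylic acid in place of the chlorine of compound 1 or the trifluoromethyl on the benzamide of compound 2.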